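The source may hold more compounds than are shown below. What is called first, only, known or untested is meant among the compounds shown, and "the series" means these compounds.

Compound 1 `CC(=O)Nc1ccc(/C=N/Nc2nc(N)c3ncn([C@@H]4O[C@H](CO)[C@@H](O)[C@H]4O)c3n2)cc1` — > 10000 nM, a limit of the assay.
Compound 2 `Nc1nc(N/N=C/c2cccc(OCc3ccccc3)c2)nc2c1ncn2[C@@H]1O[C@H](CO)[C@@H](O)[C@H]1O` — 13 nM.
Compound 3 `COc1cc(/C=N/Nc2nc(N)c3ncn([C@@H]4O[C@H](CO)[C@@H](O)[C@H]4O)c3n2)cc(OC)c1OC` — > 10000 nM, a limit of the assay.

All three were tested in an assay on CHO-K1 cells for displacement of a labelled ligand from adenosine receptor A1 (Homo sapiens), read by scintillation counting, with a stated time of 60 min; on this read-out lower numbers stand for stronger inhibition and higher numbers for weaker inhibition. Compound 1 stands at the limit of > 10000 nM in this assay, at which 2 of the 3 values shown sit; its value is a limit, not a number. Compound 3 rests at the same limit. Only compound 2 gives a number, 13 nM. Compound 4 `CCCOc1ccc(/C=N/Nc2nc(N)c3ncn([C@@H]4O[C@H](CO)[C@@H](O)[C@H]4O)c3n2)cc1` has not been measured in this assay. It differs from compound 1 in one place: propoxy in place of acetamido on an aromatic carbon. For the measured compounds named here, no step between measured compounds exists, so the expectation rests on the spread of the three values, with compound 2 at 13 nM the only sign that a group on that ring can go with a low number. The step is expected to be an at least 16-fold lower number from compound 1 to compound 4 (1.22 log units; beyond the scatter), toward lower numbers, though a limit remains possible. Compound 4 is estimated at 600 nM, between 50 nM and 10000 nM.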

Compound 4, inhibition constant: > 10000 nM
Compound 4: no number, only a limit; the forecaster's own chance of this, stated with the estimate: 30%; middle value at least 16-fold (1.22 log units) away from the limit.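

Compound 1 and compound 4 both rest at a limit in this assay, so no step between them can be read: the limit of > 10000 nM in this assay, at which 3 of the 4 values shown sit.

The compounds shown leave open whether propoxy in place of acetamido changes the read-out at all.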